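Methoxy addition in a series with no measured inhibition

The compounds below may be only part of what the source reports. "The series", "measured", "known", "first", "only" and "open" are said of these compounds alone.

Compound 3 `O=C(Nc1ccc(Sc2nc3ccccc3s2)c(Cl)c1)c1cccc(Br)c1` is the starting point. In an assay on isolated protein for inhibition of thiosulfate sulfurtransferase (Homo sapiens), with a stated time of 60 min, in the absence of a further agent (a higher number here means a weaker inhibitor, a lower number a stronger inhibitor), compound 3 gives > 100000 nM, which is a limit of the assay and not a number. Compound 1 `O=C(Nc1ccc(Sc2nc3ccccc3s2)c(Cl)c1)c1cc(Br)cc(Br)c1` gives > 100000 nM, also a limit. Compound 2 `COc1ccccc1C(=O)Nc1ccc(Sc2nc3ccccc3s2)cc1` gives > 100000 nM, again a limit. The step that the two limits leave unreadable from compound 1 to compound 3 cannot be read because of the limit of > 100000 nM in this assay, at which 3 of the 3 values shown sit. Compound 4 `COc1c(Br)cccc1C(=O)Nc1ccc(Sc2nc3ccccc3s2)c(Cl)c1` differs from compound 3 by methoxy in place of hydrogen on an aromatic carbon. Among the compounds with values here, compound 2 also carries a methoxy group and sits at its limit, so the only comparison bearing on this change gives no size. No step beyond the scatter is expected, and the estimated step that the limit leaves unreadable from compound 3 to compound 4 reflects this. Compound 4 is expected to give 150000 nM, with a range from 50000 nM to 500000 nM, most likely reported only as a limit.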

Compound 4, half-maximal inhibitory concentration: > 100000 nM
Compound 4: no number, only a limit; the forecaster's own chance of this, stated with the estimate: 85%; the middle value does not contradict the limit.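

No step can be read from compound 3 to compound 4 or from compound 1 to compound 4 in this assay, as all these results are limits: the limit of > 100000 nM in this assay, at which 4 of the 4 values shown sit.

The compounds shown leave open whether methoxy in place of hydrogen on an aromatic carbon changes inhibition at all.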